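The compounds below may be only part of what the source reports. "The series", "measured", "known", "first", "only" and "open" are said of these compounds alone.

Compound 1 `COc1ccccc1N1C(=O)/C(=C/c2ccc(OCc3ccc(C(=O)O)cc3)cc2)SC1=S`: 2000 nM
Compound 2 `Cc1ccc(N2C(=O)/C(=C/c3ccc(OCc4ccc(C(=O)O)cc4)cc3)SC2=S)cc1`: > 10000 nM

The two measured compounds share one core and differ only in the group on the amide-type nitrogen in the ring. In an assay on isolated protein for inhibition of Apoptosis regulator Bcl-2 (Homo sapiens), read by fluorescence polarization (a lower number here means a stronger inhibitor, a higher number a weaker inhibitor), compound 1 gives 2000 nM. For compound 2 the reading of > 10000 nM is a limit of the assay rather than a number (the limit of > 10000 nM in this assay, at which 1 of the 2 values shown sits). On these data alone, the step of an at least 5.0-fold higher number from compound 1 to compound 2 (0.69 log units; beyond the scatter) is therefore known only as a lower bound, and where compound 2 truly stands beyond that limit is unknown.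

Compound 3 `CC(=O)c1ccc(N2C(=O)/C(=C/c3ccc(OCc4ccc(C(=O)O)cc4)cc3)SC2=S)cc1` has not yet been measured. It differs from compound 2 by acetyl in place of methyl on an aromatic carbon. For the measured compounds named here, no measured step touches this position, so the only guide is the limit at which compound 2 sits. Compound 3 is expected to remain close to that limit, with an estimated step of a number no higher from compound 2 to compound 3 (the limit leaves the size open). The estimate for compound 3 is 10000 nM, expected to lie between 2000 nM and 50000 nM.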

Compound 3, inhibition constant: > 10000 nM
Compound 3 ended at the assay's limit; the forecaster's own chance of this, stated with the estimate: 60%; the middle value sits exactly at the limit.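

In this assay compound 3 gives > 10000 nM, which is a limit of the assay and not a number. What is new is that a second group on the ring nitrogen, 4-acetylphenyl, also reads weaker than the 2-methoxyphenyl of compound 1, with an at least 5.0-fold higher number from compound 1 to compound 3 (0.69 log units; beyond the scatter). The swap of methyl for acetyl itself cannot be read, as compound 2 and compound 3 both rest on the same limit: the limit of > 10000 nM in this assay, at which 2 of the 3 values shown sit.

On these data alone, how far past that limit compound 2 and compound 3 truly lie stays unknown, so no order between methyl and acetyl can be given. Also open, as far as these compounds go, is whether an amine or a hydroxyl group on that same aromatic carbon would bring the reading back within the measurable range, as in compound 1.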